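Phenylpiperazine amide in the aminothiazole series

This account rests on a few compounds, and the source may have more. Where it says the series, first, only, none or still open, it means among the compounds named here.

Measured so far:
compound 1 `CN1CCN(C(=O)Cn2c(-c3ccccc3)csc2=N)CC1`: 629 nM
compound 2 `N=c1scc(-c2ccc(Cl)cc2)n1CC(=O)N1CCN(c2ccccc2)CC1`: 93 nM
compound 3 `N=c1scc(-c2ccc(Cl)cc2)n1CC(=O)N1CCOCC1`: 1060 nM

In an assay on isolated protein for inhibition of leukotriene A-4 hydrolase (Homo sapiens) (on this read-out lower numbers stand for stronger inhibition and higher numbers for weaker inhibition), compound 1 stands second highest of the three numbers; compound 3 sits within the scatter of it, while compound 2 lies well beyond, at the lower end. Compound 4 `N=c1scc(-c2ccccc2)n1CC(=O)N1CCN(c2ccccc2)CC1` is not yet measured. It differs from compound 1 by phenyl in place of methyl on an amine nitrogen in a ring. Among the compounds with values here, no measured pair shows this change alone, but compound 2, which also carries the phenyl on that ring nitrogen, gives 93 nM, far below compound 1. A step downward beyond the scatter is therefore expected, estimated as a 4.2-fold lower number from compound 1 to compound 4 (0.62 log units; beyond the scatter). For compound 4 the expected value is 150 nM, in the range 50 nM to 450 nM.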

Compound 4, inhibition constant: 643 nM
For compound 4 the middle estimate is 4.3-fold (0.63 log units) below the measured one; the whole stated range lies below it.
By their numbers in this assay, from the lowest: compound 2; then compounds 1, 4 and 3 (each within the scatter of the next).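

In this assay, phenyl in place of methyl on the amine nitrogen in the ring gives a 1.0-fold higher number from compound 1 to compound 4 (0.01 log units; within the scatter) with hydrogen on the other aromatic ring, so this change alone leaves the number within the scatter. Hydrogen in place of chloro on an aromatic carbon gives a 6.9-fold higher number from compound 2 to compound 4 (0.84 log units; beyond the scatter) and thus ties the low number of compound 2 to the chloro, not to the phenyl on the ring nitrogen. No data at hand account for either step. From the compounds shown here alone, whether chloro has the same weight with methyl on that ring nitrogen remains open. So does the outcome with fluoro or methoxy in place of the chloro.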